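The source may report more compounds than this note shows. Statements on the series, on what has been measured and on what is new or still open speak of the compounds shown alone.

In a functional assay on CCRF-CEM cells (Homo sapiens) (a lower number here means a stronger inhibitor, a higher number a weaker inhibitor), compound 1 `Nc1ncnc2c1ncn2C[C@@H]1C[C@H](CO)c2ccccc21` gives 24 ug/mL. Only one close relative has been measured so far: compound 2 `OC[C@H]1C[C@@H](Cn2cnc3c(Cl)ncnc32)c2ccccc21`, which gives 24 ug/mL, leaving compound 1 level with it. The next compound to consider is compound 3 `CC(C)Nc1ncnc2c1ncn2C[C@@H]1C[C@H](CO)c2ccccc21`, which keeps the shared core of compound 1. The change is isopropyl in place of hydrogen on a nitrogen on an aromatic ring, with isopropyl in place of hydrogen on a nitrogen on an aromatic ring, so amino becomes isopropylamino.

Within the data shown here, one measured step bears on this change: no change at the digits printed from compound 1 to compound 2 (within the scatter), with chloro in place of amino on an aromatic carbon. Replacing the whole amino group therefore made no difference beyond the scatter in this assay. Among the measured compounds shown here, this is only a loose guide, since no measured compound carries isopropyl and a single step cannot show a trend. On this evidence, no step beyond the scatter is expected in either direction. The estimated change is no change at the digits printed from compound 1 to compound 3 (within the scatter), which is expected to stay within the scatter. For compound 3 the expected value is 24 ug/mL, with an estimated range from 11 ug/mL to 50 ug/mL.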

Compound 3, half-maximal inhibitory concentration: 24 ug/mL
Compound 3: middle estimate and measured number agree at the digits printed, within the range that was stated.
By their numbers in this assay, from the lowest: compounds 1, 2 and 3 (each within the scatter of the next).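

Among these compounds, the amino group of compound 1 had so far only been replaced as a whole, whereas compound 3 keeps its nitrogen and adds isopropyl, 3 heavy atoms, to it. In this assay this addition gives no change at the digits printed from compound 1 to compound 3 (within the scatter) and the exchange of chloro for isopropylamino on the aromatic carbon gives no change at the digits printed from compound 2 to compound 3 (within the scatter), so amino, chloro and isopropylamino all sit at this position with values that cannot be told apart. Nothing available explains why these three groups give the same reading.

From the compounds shown here alone, whether this flat picture would hold for a larger group on the nitrogen, such as benzyl, or for a carboxylic acid in place of the amino group remains open. All three compounds also share the rest of their structure, so they cannot show whether this assay would respond to a change made elsewhere on the shared core.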